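From Compound 2 to a Hydroxylated Compound 3

The source may hold more compounds than are shown below. What is called first, only, known or untested is meant among the compounds shown, and "the series" means these compounds.

In a functional assay on Lu1 cells (Homo sapiens) for cytotoxicity, read by colorimetric assay and neutral red uptake, with a stated time of 72 h (on this read-out higher numbers stand for weaker inhibition and lower numbers for stronger inhibition), compound 2 `CO[C@@H](C(=O)N[C@@H]1CCCCNC1=O)[C@H](O)[C@@H](O)[C@H](O)/C=C/C(C)(C)C` gives 500 nM, the lower of the two numbers, while compound 1 `CO[C@@H](C(=O)N[C@H]1CCCCNC1=O)[C@H](O)[C@@H](O)[C@H](O)/C=C/C(C)(C)C` gives 4300 nM. Going by the values given here, the only measured step, an 8.6-fold lower number from compound 1 to compound 2 (0.93 log units; beyond the scatter), comes with the fact that compounds 1 and 2 differ only in the configuration as drawn. Compound 3 `CO[C@@H](C(=O)N[C@H]1CC[C@H](O)CNC1=O)[C@H](O)[C@@H](O)[C@H](O)/C=C/C(C)(C)C` departs from compound 2 by 6-hydroxy-2-oxoazepan-3-yl in place of 2-oxoazepan-3-yl on an amide-type nitrogen. Among the compounds with values here, no measured step covers the added hydroxy group, but the stereocentre separating compound 1 from compound 2 is drawn in compound 3 as in compound 1, which stands at 4300 nM. A higher number is therefore expected in this assay for compound 3, an estimated 4.0-fold higher number from compound 2 to compound 3 (0.60 log units; beyond the scatter). For compound 3 the estimated value is 2000 nM, with an expected range of 300 nM to 10000 nM.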

Compound 3, half-maximal inhibitory concentration: 10000 nM
Compound 3: middle estimate off by 5.0-fold (0.70 log units), on the low side; the range from low to high includes it.
By their numbers in this assay, from the lowest: compound 2; then compound 1; then compound 3.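

Hydroxy in place of hydrogen on a saturated ring carbon now has a reading of its own in this assay: a 2.3-fold higher number from compound 1 to compound 3 (0.37 log units; beyond the scatter). The replacement of 2-oxoazepan-3-yl by 6-hydroxy-2-oxoazepan-3-yl gives the larger 20-fold higher number from compound 2 to compound 3 (1.30 log units; beyond the scatter), but this step also includes the stereocentre drawn as in compound 1, and that stereocentre alone separates the two earlier compounds: the fact that compounds 1 and 2 differ only in the configuration as drawn.

Going by these compounds, it remains open how the hydroxy group would read with the configuration of compound 2, and whether a methoxy group or an amine in its place would give a similar number.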